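The source may hold more compounds than are shown below. What is called first, only, known or untested is meant among the compounds shown, and "the series" means these compounds.

Of the compounds shown here, three of one shared core have been tested in an ADME assay on HEK293 cells (Homo sapiens) for cytotoxicity, read by MTT assay, with a stated time of 48 h (on this read-out lower numbers stand for stronger inhibition and higher numbers for weaker inhibition), and every one of them reached only the top of the measurable range. Compound 2 `CN(c1ccc(NC(=O)c2ccc(C(F)(F)F)cc2C(F)(F)F)cc1OCc1cccc(C(F)(F)F)c1)S(C)(=O)=O` gives > 500000 nM in this assay, and that figure is a limit rather than a number. Compound 1 `CN(c1ccc(NC(=O)c2cc(C(F)(F)F)cc(C(F)(F)F)c2)cc1OCc1cccc(C(F)(F)F)c1)S(C)(=O)=O` gives > 500000 nM in this assay, again a limit. Compound 3 `CN(c1ccc(NC(=O)c2cc(C(F)(F)F)cc(C(F)(F)F)c2)cc1OCc1ccccc1C(F)(F)F)S(C)(=O)=O` gives > 500000 nM in this assay, also a limit. Going by the values given here, the only single-point comparison among them, a step that the two limits leave unreadable from compound 1 to compound 3, is therefore unreadable in size, since the limit of > 500000 nM in this assay, at which 3 of the 3 values shown sit, holds every value shown.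

Compound 4 `CCCCCCOc1cc(NC(=O)c2ccc(C(F)(F)F)cc2C(F)(F)F)ccc1N(C)S(C)(=O)=O` is the next member of the series. It differs from compound 2 in one place: pentyl in place of 3-(trifluoromethyl)phenyl on a saturated chain carbon bound to an oxygen on an aromatic ring, so the benzyl ether of compound 2 becomes a plain hexyloxy chain. Among the compounds with values here, no measured step describes what a change of this kind does in this assay, and the comparison between compound 1 and compound 3, which swaps one trifluoromethylphenyl for another, gives no readable size either. The expectation for compound 4 is thus a step of a number no higher from compound 2 to compound 4 (the limit leaves the size open) that cannot be distinguished from none, with the value most likely again ending at the limit. Compound 4 is estimated at 500000 nM, in a range from 200000 nM to 1000000 nM.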

Compound 4, half-maximal inhibitory concentration: > 500000 nM
Compound 4 gave a limit, no number; the forecaster's own chance of this, stated with the estimate: 80%; the middle value lies on the limit itself.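

In this assay compound 4 gives > 500000 nM, which is a limit and not a number. Compound 2 also stands at a limit, so no size can be read for the change from compound 2 to compound 4. The compounds shown leave open whether any change on the shared core would give a measurable value in this assay.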